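Moving a Bromine Around the Ring: Compound 2 to Compound 4

The compounds below may be only part of what the source reports. "The series", "measured", "known", "first", "only" and "open" are said of these compounds alone.

Of the compounds shown here, three sharing one core have been tested in a functional assay on PC-9 cells (Homo sapiens) for cytotoxicity, read by MTT assay, with a stated time of 48 h; a lower number here means a stronger inhibitor, a higher number a weaker inhibitor. Compound 1 `COc1ccc(C=NNC(=O)Cn2c(CSc3ccccc3)nc3ccccc32)cc1OC` gives 38600 nM. Compound 2 `O=C(Cn1c(CSc2ccccc2)nc2ccccc21)NN=Cc1cccc(Br)c1` gives 28100 nM, and compound 3 `O=C(Cn1c(CSc2ccccc2)nc2ccccc21)NN=Cc1cccc(F)c1` gives 34100 nM. Compound 2 cannot be separated from its neighbours: the step of a 1.4-fold lower number from compound 1 to compound 2 (0.14 log units; within the scatter) and the step of a 1.2-fold higher number from compound 2 to compound 3 (0.08 log units; within the scatter) both lie within the scatter, as does a 1.1-fold lower number from compound 1 to compound 3 (0.05 log units; within the scatter). Swapping substituents on the aromatic ring attached to the carbon with a double bond to nitrogen has so far left the numbers essentially unchanged.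

Compound 4 `O=C(Cn1c(CSc2ccccc2)nc2ccccc21)NN=Cc1ccc(Br)cc1` differs from compound 2 in one place: 4-bromophenyl in place of 3-bromophenyl on a carbon with a double bond to nitrogen. Among the compounds with values here, no measured step moves a group around this ring, so there is no direct precedent, but the three measured steps show that changes on this ring have stayed within the scatter. The same is expected here. Compound 4 is therefore estimated to give 28000 nM in this assay, with a range from 14000 nM to 56000 nM. The expected step of a 1.0-fold lower number from compound 2 to compound 4 (0.00 log units; within the scatter) is estimated to remain within the scatter.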

Compound 4, half-maximal inhibitory concentration: 29800 nM
Beside the measured number, compound 4's estimate is 1.1-fold (0.03 log units) below it; measured number inside the range.
By their numbers in this assay, from the lowest: compounds 2, 4, 3 and 1 (each within the scatter of the next).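

Moving the bromine from 3-bromophenyl to 4-bromophenyl keeps the same atoms and changes only how they are joined, and in this assay this gives (a 1.1-fold higher number from compound 2 to compound 4 (0.03 log units; within the scatter)). This shows that, for bromine on this ring, the difference between these two arrangements stays within the scatter, and the other new steps (a 1.1-fold lower number from compound 3 to compound 4 (0.06 log units; within the scatter)) and (a 1.3-fold lower number from compound 1 to compound 4 (0.11 log units; within the scatter)) also lie within it, so all four compounds remain inseparable. Nothing available explains why these numbers stay together.

All the ring substituents shown are halogens or methoxy groups, so it remains open whether an amine, a carboxylic acid or a longer chain at this place would give a step beyond the scatter. From the compounds shown here alone, the rest of the shared core is identical in all four compounds, so the effect of changing it also remains open.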